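The source may report more compounds than this note shows. Statements on the series, on what has been measured and on what is new or still open speak of the compounds shown alone.

Compound 3, `CCN(Cc1ccc(F)cc1)c1ccc(C(=O)N2CCc3ccc(OS(N)(=O)=O)cc3C2)cc1`, carries the shared core with an ethyl(4-fluorobenzyl)amino group on the aromatic carbon. Within the data shown here, in an assay on HEK293 cells for inhibition of Steryl-sulfatase (Homo sapiens), tested at 0.1 uM (on this read-out lower numbers stand for a weaker effect and higher numbers for a stronger effect at the one concentration tested), compound 3 gives 69.1%, the highest of the three numbers so far. Compound 2, `CCN(Cc1ccccn1)c1ccc(C(=O)N2CCc3ccc(OS(N)(=O)=O)cc3C2)cc1`, gives 42.5%, and compound 1, `CN(C)CCN(CCN(C)C)c1ccc(C(=O)N2CCc3ccc(OS(N)(=O)=O)cc3C2)cc1`, gives 3.8%. The step of a number 26.6 percentage points higher from compound 2 to compound 3 (beyond the scatter) and the larger step of a number 65.3 percentage points higher from compound 1 to compound 3 (beyond the scatter) both show that the amino substituent on this aromatic carbon governs most of the spread among these compounds, with a number 38.7 percentage points higher from compound 1 to compound 2 (beyond the scatter) filling in the remaining gap.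

Compound 4, `CCCN(CCC)c1ccc(C(=O)N2CCc3ccc(OS(N)(=O)=O)cc3C2)cc1`, differs from compound 3 in one place: dipropylamino in place of ethyl(4-fluorobenzyl)amino on an aromatic carbon. The dipropylamino group keeps a nitrogen bearing two alkyl chains but drops the six-membered aromatic ring. Among the measured compounds shown here, the steps that bear on this are a number 65.3 percentage points higher from compound 1 to compound 3 (beyond the scatter) and a number 26.6 percentage points higher from compound 2 to compound 3 (beyond the scatter), both of which end at compound 3 and both of which were large or modest in its favour. For the measured compounds named here, compound 1, the one measured compound without an aromatic group on this nitrogen, gives 3.8%, but its bis(2-(dimethylamino)ethyl)amino group is unlike dipropylamino, so that number is only a loose guide. A drop beyond the scatter is therefore expected, a number 29.1 percentage points lower from compound 3 to compound 4 (beyond the scatter), without falling as far as compound 1. Compound 4 is estimated at 40%, in a range from 15% to 65%.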

Compound 4, a percentage reported as inhibition, at one concentration (the size of the read-out at that concentration, not a potency): 36.6%
Beside the measured number, compound 4's estimate is 3.4 percentage points above it; the measured number falls inside the stated range.
By their numbers in this assay, from the lowest: compound 1; then compounds 4 and 2 (each within the scatter of the next); then compound 3.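

In this assay, exchanging ethyl(4-fluorobenzyl)amino for dipropylamino, which removes the six-membered aromatic ring of carbon only, gives a number 32.5 percentage points lower from compound 3 to compound 4 (beyond the scatter) and so shows that two plain propyl chains on this nitrogen do not hold the top level of the series. Exchanging ethyl((pyridin-2-yl)methyl)amino for dipropylamino gives a number 5.9 percentage points lower from compound 2 to compound 4 (within the scatter) and so shows that an aromatic ring on this nitrogen does not by itself set a group apart, since the pyridinyl-bearing group and the ring-free group cannot be told apart on this read-out. Exchanging bis(2-(dimethylamino)ethyl)amino for dipropylamino gives a number 32.8 percentage points higher from compound 1 to compound 4 (beyond the scatter) and so shows that a group without a ring can still stand well clear of the lowest number, which means the absence of a ring does not alone mark the low end.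

Nothing measured here accounts for these differences. Still open, as far as these compounds go, is whether an unsubstituted benzyl group, a longer chain in place of the propyl chains or a carboxylic acid on one of those chains would read nearer to the 4-fluorobenzyl group or to dipropylamino at this position.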